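The source may report more compounds than this note shows. Statements on the series, on what has been measured and on what is new or still open speak of the compounds shown alone.

Compound 1 `CC(C)n1cc(-c2ccnc3[nH]c(C4CCNCC4)cc23)ccc1=O`: 910000 nM
Compound 2 `CC(C)n1cc(-c2ccnc3[nH]c(C4CCN(Cc5cccs5)CC4)cc23)ccc1=O`: 25000 nM

Going by the values given here, in a physicochemical assay for solubility, in phosphate buffer, at pH 7.4 (a higher number here means a more soluble compound, a lower number a less soluble compound), compound 2 gives 25000 nM, the lower of the two numbers so far. Compound 3 `CC(C)n1cc(-c2ccnc3[nH]c(C4CCN(CC(=O)N5CCCCC5)CC4)cc23)ccc1=O` differs from compound 2 on a saturated chain carbon bound to an amine nitrogen in a ring: (piperidin-1-yl)carbonyl in place of thiophen-2-yl on a saturated chain carbon bound to an amine nitrogen in a ring. Among the compounds with values here, the one measured step that bears on this is large: a 36-fold lower number from compound 1 to compound 2 (1.56 log units; beyond the scatter). That step put a group in place of hydrogen, whereas here one group replaces another, so a smaller, modest upward change is expected. The estimated step is a 2.4-fold higher number from compound 2 to compound 3 (0.38 log units; beyond the scatter). Compound 3 is expected at 60000 nM, with an estimated range of 18000 nM to 220000 nM.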

Compound 3, solubility: 79000 nM
Estimate against measurement, compound 3: 1.3-fold (0.12 log units) below, and the stated range covers the measured number.
By their numbers in this assay, from the lowest: compound 2; then compound 3; then compound 1.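

In this assay, the group on a saturated chain carbon bound to an amine nitrogen in a ring matters: (piperidin-1-yl)carbonyl in place of thiophen-2-yl gives a 3.2-fold higher number from compound 2 to compound 3 (0.50 log units; beyond the scatter) here. So the drop seen with the first substituent is not fixed, although ((piperidin-1-yl)carbonyl)methyl on the amine nitrogen in a ring still gives a 12-fold lower number from compound 1 to compound 3 (1.06 log units; beyond the scatter) overall. Nothing available explains why these groups differ. Still open, going by these compounds, is where a carboxylic acid, a primary amine or a longer chain at this place would fall relative to compound 1 and compound 3.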